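Swapping chloro for methoxy in compound 3

This account rests on a few compounds, and the source may have more. Where it says the series, first, only, none or still open, it means among the compounds named here.

Values in a functional assay on ECa-109 cells (Homo sapiens) for cytotoxicity, read by MTT assay, with a stated time of 72 h; a higher number here means a weaker inhibitor, a lower number a stronger inhibitor:
- compound 1 `O=C1C(=Cc2ccc(F)cc2)C(=O)N(c2ccc(Cl)cc2)N1c1ccc(Cl)cc1`: 35600 nM
- compound 2 `O=C1C(=Cc2ccc(Br)cc2)C(=O)N(c2ccc(Cl)cc2)N1c1ccc(Cl)cc1`: 12300 nM
- compound 3 `O=C1C(=Cc2cccc(Cl)c2)C(=O)N(c2ccc(Cl)cc2)N1c1ccc(Cl)cc1`: 22600 nM

Compound 3 cannot be separated from either of the other two compounds. Both a 1.6-fold lower number from compound 1 to compound 3 (0.20 log units; within the scatter) and a 1.8-fold higher number from compound 2 to compound 3 (0.26 log units; within the scatter) stay within the scatter, whereas a 2.9-fold lower number from compound 1 to compound 2 (0.46 log units; beyond the scatter) goes beyond it, though only modestly.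

The account now turns to compound 4 `COc1cccc(C=C2C(=O)N(c3ccc(Cl)cc3)N(c3ccc(Cl)cc3)C2=O)c1`, which differs from compound 3 by a single change, methoxy in place of chloro on an aromatic carbon, meta to a large group. Among the measured compounds shown here, no measured step makes this exchange, so the evidence is indirect. For the measured compounds named here, the steps that bear on it are those that alter the same aryl group, and the largest of these, a 2.9-fold lower number from compound 1 to compound 2 (0.46 log units; beyond the scatter), is modest. The step closest to the new change, a 1.8-fold higher number from compound 2 to compound 3 (0.26 log units; within the scatter), also involves the 3-chlorophenyl group and is within the scatter. On that basis, no step beyond the scatter is expected in this assay, and no direction can be favoured. The expected change is a 1.1-fold higher number from compound 3 to compound 4 (0.04 log units; within the scatter), which would remain within the scatter. Compound 4 is estimated at 25000 nM, with an expected range of 11000 nM to 55000 nM.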

Compound 4, half-maximal inhibitory concentration: 29000 nM
Compound 4: middle estimate off by 1.2-fold (0.06 log units), on the low side; measured number inside the range.
By their numbers in this assay, from the lowest: compounds 2, 3, 4 and 1 (each within the scatter of the next, the first and the last beyond it).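

In this assay, methoxy in place of chloro on an aromatic carbon, meta to a large group, gives a 1.3-fold higher number from compound 3 to compound 4 (0.11 log units; within the scatter), so this direct exchange leaves compound 3 and compound 4 inseparable, even though methoxy carries a hydrogen-bond acceptor that is not counted for chloro. The new 3-methoxyphenyl compound also cannot be separated from the 4-fluorophenyl compound, with a 1.2-fold lower number from compound 1 to compound 4 (0.09 log units; within the scatter), while a 2.4-fold higher number from compound 2 to compound 4 (0.37 log units; beyond the scatter) goes beyond the scatter, though only modestly, so compound 2 now stands apart from both compound 1 and compound 4 but still not from compound 3. No measurement shown accounts for any of these steps.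

The compounds shown leave open whether an amine, a carboxylic acid or a hydroxyl group on this aromatic carbon would produce a step beyond the scatter from compound 3. On these data alone, the two chlorophenyl groups also stay the same across all four compounds, so the effect of exchanging either of them, for example for an unsubstituted phenyl, remains unknown in this assay.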